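Moving the acetyl group: compound 1 to compound 4

A few compounds are considered here, and "the series" means these few. Any claim that something is new, unique, unknown or untested is made for them only; others in the source may bear on it.

Of the compounds shown here, three sharing one core have been measured in a functional assay on RPMI-8226 cells (Homo sapiens) for inhibition, read by sulforhodamine B assay, with a stated time of 48 h, tested at 10 uM; on this read-out higher numbers stand for more inhibition of growth at the one concentration tested and lower numbers for less inhibition of growth. Compound 1 `CC(=O)c1cccc(Nc2ccnc(SCC(=O)c3ccc(-c4ccccc4)cc3)n2)c1` gives 34%, which is the second highest of the three numbers. Compound 2 `CC(=O)c1cccc(Nc2ccnc(SCC(=O)c3ccc(C(F)(F)F)cc3)n2)c1` gives 31% in this assay, and compound 3 `CCOC(=O)c1ccc(Nc2ccnc(SCC(=O)c3ccc([N+](=O)[O-])cc3)n2)cc1` gives 54%, a number beyond the scatter above that of compound 1.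

The compound still to be measured is compound 4 `CC(=O)c1ccc(Nc2ccnc(SCC(=O)c3ccc(-c4ccccc4)cc3)n2)cc1`. It has the same atoms as compound 1, joined differently: 4-acetylphenyl in place of 3-acetylphenyl on a nitrogen on an aromatic ring. For the measured compounds named here, the one measured step between two compounds that differ in a single place is a number 3 percentage points lower from compound 1 to compound 2 (within the scatter), a change at the other end of the molecule, so it does not speak to the present change. Going by the values given here, no pair of measured compounds differs only in the arrangement of the acetylphenyl group, so the data give no direction for this step.

With nothing to push the number either way, the step is expected to stay within the usual scatter, with a number 2 percentage points higher from compound 1 to compound 4 (within the scatter) as the estimated change in this assay. Compound 4 is therefore expected to give about 36% in this assay, in a range from 20% to 52%.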

Compound 4, percent growth inhibition at one concentration: 26%
Estimate against measurement, compound 4: 10 percentage points above; the range from low to high includes it.
By their numbers in this assay, from the lowest: compounds 4, 2 and 1 (each within the scatter of the next); then compound 3.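

In this assay, moving the acetyl group from the 3-acetylphenyl arrangement to the 4-acetylphenyl arrangement gives a number 8 percentage points lower from compound 1 to compound 4 (within the scatter) and stays inside the usual scatter, so this read-out does not separate the two arrangements. For the compounds shown here, this is the first measured change on the acetylphenyl end of the molecule, and the earlier step concerned only the other end: with the biphenyl-type group held constant, the place of the acetyl group on this ring has no effect that can be told from scatter at the one concentration tested. No further measurement bears on what lies behind this result.

Going by these compounds alone, only two arrangements of one group on this ring are covered here, so it remains open whether a different group on the ring, such as a carboxylic acid or a primary amine in place of the acetyl group, would shift the growth inhibition beyond the scatter. Compound 3 also stays unexplained, since it differs from compound 4 at both ends of the molecule, and a single step cannot be drawn from that pair.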